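A Fluorine Added to the Phenyl of Compound 2

A few compounds are considered here, and "the series" means these few. Any claim that something is new, unique, unknown or untested is made for them only; others in the source may bear on it.

Measured so far:
compound 1 `COc1ccc(Cn2cc(CO/N=C/c3c(-c4ccccc4)nc4c(C)cccn34)nn2)cc1` gives 100 mg/kg
compound 2 `Cc1cccn2c(/C=N/OCc3cn(Cc4ccc(C#N)cc4)nn3)c(-c3ccccc3)nc12` gives 40 mg/kg
compound 3 `Cc1ccc(-c2nc3c(C)cccn3c2/C=N/OCc2cn(Cc3ccc([N+](=O)[O-])cc3)nn2)cc1` gives 20 mg/kg

In a functional assay on the whole organism (strain NMRI) with Mus musculus as the target, with a stated time of 4 h (on this read-out higher numbers stand for an effect only at larger amounts of compound and lower numbers for an effect already at smaller amounts), compound 2 stands second highest of the three numbers. Its neighbour on the scale is compound 3, whose value lies within the scatter of compound 2, so the two cannot be ordered; compound 1 lies further away, and the step of a 2.5-fold lower number from compound 1 to compound 2 (0.40 log units; beyond the scatter) is beyond the scatter.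

Compound 4 `Cc1cccn2c(/C=N/OCc3cn(Cc4ccc(C#N)cc4)nn3)c(-c3ccc(F)cc3)nc12` is the next compound to be measured. It differs from compound 2 by fluoro in place of hydrogen on an aromatic carbon

For the measured compounds named here, no measured step concerns a change on this phenyl ring: the only measured step, a 2.5-fold lower number from compound 1 to compound 2 (0.40 log units; beyond the scatter), alters the group on the benzyl part instead, and compound 3 differs from compound 2 in two places at once, so its value alone cannot be attributed to the phenyl. With nothing to lean on, a step of only modest size is expected in this assay, with no confident direction.

Compound 4 is therefore estimated at 40 mg/kg, with a range from 20 mg/kg to 80 mg/kg. The expected step of no change at the digits printed from compound 2 to compound 4 (within the scatter) is one within the scatter.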

Compound 4, minimum effective dose: 40 mg/kg
Beside the measured number, compound 4's estimate shows no gap at the digits printed; the range from low to high includes it.
By their numbers in this assay, from the lowest: compounds 3, 2 and 4 (each within the scatter of the next); then compound 1.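

In this assay, for the compounds shown here, the change from phenyl to 4-fluorophenyl gives no change at the digits printed from compound 2 to compound 4 (within the scatter) and is the first reading taken on this ring, since the earlier single step concerned the benzyl part. The reading shows that this carbon can carry one fluoro in place of hydrogen while the compound keeps its effect in the whole animal, at a dose that cannot be told apart from that of the parent compound. No measured property is at hand to account for this result.

From the compounds shown here alone, whether an amine or a carboxylic acid at the same carbon would leave the dose equally undisturbed remains open. Going by these compounds, it is also open whether fluoro on another carbon of this ring, or on the benzyl part, would give the same picture.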